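Swapping the aromatic cap on the amide of compound 2

This account rests on a few compounds, and the source may have more. Where it says the series, first, only, none or still open, it means among the compounds named here.

For the measured compounds named here, compound 2 `N=C(N)NCCC[C@@H](NC(=O)c1ccc(F)c2ccccc12)C(=O)NCc1ccc(C(F)(F)F)cc1` is the stronger of the two compounds measured so far: in a functional assay on HEK293 cells for antagonist activity at melanin-concentrating hormone receptor 1 (Homo sapiens) (a lower number here means a stronger inhibitor, a higher number a weaker inhibitor), compound 2 gives 311 nM. Going by the values given here, its only neighbour is compound 1 `N=C(N)NCCC[C@@H](NC(=O)c1cc2ccccc2cn1)C(=O)NCc1ccc(C(F)(F)F)cc1`, which in this assay gives 1810 nM; the step of a 5.8-fold lower number from compound 1 to compound 2 (0.76 log units; beyond the scatter) is the one change recorded at this position, and it shows that replacing the aromatic group on the carbonyl carbon can shift the number well beyond the scatter.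

Compound 3 `COc1cccc2cc(C(=O)N[C@H](CCCNC(=N)N)C(=O)NCc3ccc(C(F)(F)F)cc3)oc12` is not yet measured. It differs from compound 2 in one place: 7-methoxy-1-benzofuran-2-yl in place of 4-fluoronaphthalen-1-yl on a carbonyl carbon. Among the compounds with values here, the only measured step bears on this change indirectly, because a 5.8-fold lower number from compound 1 to compound 2 (0.76 log units; beyond the scatter) shows that a ring-for-ring swap at this carbonyl matters, without telling which way a new ring will move the number. Given that uncertainty, compound 3 is expected to land on the weaker side of compound 2, with the estimated step of a 2.1-fold higher number from compound 2 to compound 3 (0.32 log units; beyond the scatter). The estimate for compound 3 in this assay is therefore 650 nM, within a range from 150 nM to 2800 nM.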

Compound 3, half-maximal inhibitory concentration: 622 nM
Estimate against measurement, compound 3: 1.0-fold (0.02 log units) above; low and high end bracket the measured number.
By their numbers in this assay, from the lowest: compounds 2 and 3 (each within the scatter of the next); then compound 1.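

In this assay, the step of a 2.0-fold higher number from compound 2 to compound 3 (0.30 log units; within the scatter) shows that two quite different groups on this carbonyl carbon cannot be told apart by their numbers: 4-fluoronaphthalen-1-yl has 2 six-membered aromatic rings of carbon only and 0 hydrogen-bond acceptors, whereas 7-methoxy-1-benzofuran-2-yl has a five-membered aromatic ring with 1 hetero atom and 2 hydrogen-bond acceptors. The step of a 2.9-fold lower number from compound 1 to compound 3 (0.46 log units; beyond the scatter) lies beyond the scatter, so isoquinolin-3-yl now stands apart from both other groups, not only from the 4-fluoronaphthalen-1-yl of compound 2. Nothing measured here explains why compound 1 differs from the other two.

From the compounds shown here alone, compound 3 differs from compound 2 in both its ring system and its substituent, so the part played by the methoxy group alone stays open, and a plain 1-benzofuran-2-yl or a 7-hydroxy-1-benzofuran-2-yl group would help to separate the two. It also remains open how a single ring, such as a phenyl or a pyridine, would behave at this carbonyl carbon, since all three groups shown have two fused rings.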